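A few compounds are considered here, and "the series" means these few. Any claim that something is new, unique, unknown or untested is made for them only; others in the source may bear on it.

Measured in an ADME assay on HEL cells (Homo sapiens) for cytotoxicity; on this read-out higher numbers stand for lower toxicity in this test and lower numbers for higher toxicity in this test:

compound 1 `O=C(COc1cccc2ccccc12)N/N=C/c1ccc(Cl)cc1`: 100 ug/mL
compound 2 `O=C(COc1cccc2ccccc12)N/N=C/c1ccc(O)cc1`: 60.6 ug/mL
compound 3 `CSc1ccc(/C=N/NC(=O)COc2cccc3ccccc23)cc1`: a limit, > 100 ug/mL

Within the data shown here, compound 3 therefore gives no number, only a limit of this assay; it is the one value among the three that sits at the limit of > 100 ug/mL in this assay, at which 1 of the 3 values shown sits. Compound 4 `O=C(COc1cccc2ccccc12)N/N=C/c1cccc(Br)c1` differs from it by 3-bromophenyl in place of 4-(methylsulfanyl)phenyl on a carbon with a double bond to nitrogen. Among the measured compounds shown here, two measured steps bear on this change: a number no lower from compound 1 to compound 3 (the limit leaves the size open) and an at least 1.6-fold higher number from compound 2 to compound 3 (0.21 log units; that floor lies within the scatter), where compound 1 carries a chloro group. Since compound 1 gives a number at the edge of the limit, the bromo analogue is expected to land near it: the estimate for compound 4 is 100 ug/mL, with a range from 50 ug/mL to 200 ug/mL, meaning a number no higher from compound 3 to compound 4 (the limit leaves the size open), a step not expected to exceed the scatter.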

Compound 4, half-maximal cytotoxic concentration: 48.6 ug/mL
The estimate for compound 4 lay 2.1-fold (0.31 log units) above the measured number; the measured number lies below the stated range.
By their numbers in this assay, from the lowest: compounds 4, 2 and 1 (each within the scatter of the next, the first and the last beyond it).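

In this assay, among these compounds, 3-bromophenyl on the carbon with a double bond to nitrogen gives the first measured change here that clearly exceeds the scatter: a 2.1-fold lower number from compound 1 to compound 4 (0.31 log units; beyond the scatter). Against 4-hydroxyphenyl, the change is no larger than the scatter: a 1.2-fold lower number from compound 2 to compound 4 (0.10 log units; within the scatter). The step from 4-(methylsulfanyl)phenyl, an at least 2.0-fold lower number from compound 3 to compound 4 (0.31 log units; beyond the scatter), gives only a floor, because compound 3 is a limit: the limit of > 100 ug/mL in this assay, at which 1 of the 4 values shown sits.

Compound 4 differs from compound 1 in both the halogen and its place on the ring, and these two changes cannot be separated here. On these data alone, how a phenyl ring carrying an amine or a carboxylic acid would read remains open.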